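Methoxyphenyl for Methylphenyl: What to Expect of Compound 3

The compounds below may be only part of what the source reports. "The series", "measured", "known", "first", "only" and "open" are said of these compounds alone.

Of the compounds shown here, two in this set have been tested in a functional assay on HepG2 cells (Homo sapiens) for antiproliferative activity, read by MTT assay, with a stated time of 48 h; on this read-out lower numbers stand for stronger inhibition and higher numbers for weaker inhibition. Compound 1 `N#CC1=C(N)Oc2c(c3nc4ccccc4nc3c3ccccc23)C12C(=O)N(Cc1cnnn1-c1ccc(N)cc1)c1ccccc12` gives in this assay only a limit of > 50000 nM, not a number. Compound 2 `Cc1ccccc1-n1nncc1CN1C(=O)C2(C(C#N)=C(N)Oc3c(N)cc4nc5ccccc5nc4c32)c2ccccc21` likewise gives only a limit of > 50000 nM in this assay. Compound 2 thus stands at the limit of > 50000 nM in this assay, at which 2 of the 2 values shown sit, and no measured value in the set sets it apart from compound 1. Within the data shown here, no pair of measured compounds differing in a single place is available, so no measured step can guide the next change.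

Compound 3 `COc1ccc(-n2nncc2CN2C(=O)C3(C(C#N)=C(N)Oc4c(N)cc5nc6ccccc6nc5c43)c3ccccc32)cc1` is not yet measured. It differs from compound 2 by 4-methoxyphenyl in place of 2-methylphenyl on an aromatic nitrogen. The change touches only the group on that aromatic nitrogen and leaves the rest of the shared core untouched. Among the measured compounds shown here, nothing among the measured compounds shows a shift in this assay from any change, so no step beyond the scatter is expected in either direction. The expected step is a number no higher from compound 2 to compound 3 (the limit leaves the size open). Compound 3 is therefore expected to give about 50000 nM in this assay, most likely again as a limit rather than a number, within a range of 20000 nM to 120000 nM.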

Compound 3, half-maximal inhibitory concentration: > 50000 nM
Compound 3 was reported as a limit; the forecaster's own chance of this, stated with the estimate: 80%; the middle value sits exactly at the limit.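

Among these compounds, compound 3, like compound 2, gives only a limit in this assay, so no step from one to the other can be read. Both stand at the same place: the limit of > 50000 nM in this assay, at which 3 of the 3 values shown sit.

The compounds shown leave open whether any group on that aromatic nitrogen, or any change to the shared core, gives an actual number in this assay.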